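This account rests on a few compounds, and the source may have more. Where it says the series, first, only, none or still open, it means among the compounds named here.

Within the data shown here, compound 1 `Oc1ccc(-c2cc(-c3ccco3)nc(-c3ccccc3Cl)c2)cc1` is the only compound here that carries a number: in a functional assay on T47D cells (Homo sapiens) for cytotoxicity, read by CCK-8 assay and cell counting, with a stated time of 2 days (a lower number here means a stronger inhibitor, a higher number a weaker inhibitor), compound 1 gives 5480 nM. Compound 2 `Oc1ccc(-c2cc(-c3cccnc3)nc(-c3ccccc3Cl)c2)cc1` has no result, since in this assay compound 2 gives "not determined" (no result reported). Compound 3 `Oc1cccc(-c2cc(-c3ccco3)nc(-c3ccccc3Cl)c2)c1` keeps the same atoms joined differently: 3-hydroxyphenyl in place of 4-hydroxyphenyl on an aromatic carbon. Among the measured compounds shown here, no step between measured compounds exists to guide this. The step is expected to be small, a 1.3-fold higher number from compound 1 to compound 3 (0.11 log units; within the scatter), lying within or just beyond the scatter and, if anything, toward weaker inhibition. Compound 3 is therefore estimated at 7000 nM, between 2500 nM and 20000 nM.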

Compound 3, half-maximal inhibitory concentration: 2010 nM
Beside the measured number, compound 3's estimate is 3.5-fold (0.54 log units) above it; measured number outside the range, below it.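

With 3-hydroxyphenyl in place of 4-hydroxyphenyl on the aromatic carbon opposite the ring nitrogen, this assay records a 2.7-fold lower number from compound 1 to compound 3 (0.44 log units; beyond the scatter). This shows that the number at this position responds to where the hydroxyl sits on the phenyl group, even with the same atoms, and in this pair the 3-hydroxyphenyl group gives the stronger inhibition. Nothing given here explains the step. As far as these compounds go, it remains open whether 2-hydroxyphenyl would continue this shift. From the compounds shown here alone, it is also open whether a methoxy group or an amine could take the place of the hydroxyl.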